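Changing the Ring on the Sulfonyl Sulfur of Compound 1

The source may report more compounds than this note shows. Statements on the series, on what has been measured and on what is new or still open speak of the compounds shown alone.

In a functional assay on A549 cells (Homo sapiens) for antiproliferative activity, read by MTT assay, with a stated time of 72 h (on this read-out higher numbers stand for weaker inhibition and lower numbers for stronger inhibition), compound 1 (`CCn1cc(C(=O)O)c(=O)c2cc(F)c(N3CCN(C(=N)NS(=O)(=O)c4ccc(C(F)(F)F)cc4)CC3)cc21`) gives 71 nM while compound 2 (`N=C(NS(=O)(=O)c1ccccc1)N1CCN(c2cc3c(cc2F)c(=O)c(C(=O)O)cn3C2CC2)CC1`) gives 71 nM and the two stand level, so neither can be ranked above the other. The next molecule, compound 3 (`CCn1cc(C(=O)O)c(=O)c2cc(F)c(N3CCN(C(=N)NS(=O)(=O)c4cccc(Cl)c4)CC3)cc21`), has not yet been tested. It carries 3-chlorophenyl in place of 4-(trifluoromethyl)phenyl on a sulfonyl sulfur, and the rest of compound 1 stays as it is (3-chlorophenyl in place of 4-(trifluoromethyl)phenyl on a sulfonyl sulfur). Going by the values given here, no measured pair here shows what a change at this spot alone does, so the data give no direct rule for it. Among the compounds with values here, the only guide is the level pair of values, and it points in no direction. No change beyond the usual scatter is therefore expected in this assay with at most a slight drift toward weaker inhibition. The estimated move, a 1.3-fold higher number from compound 1 to compound 3 (0.10 log units; within the scatter), is small and stays within that scatter. For compound 3 the estimated half-maximal inhibitory concentration is 90 nM with an expected range from 30 nM to 280 nM across repeat measurements.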

Compound 3, half-maximal inhibitory concentration: 71 nM
Compound 3: middle estimate off by 1.3-fold (0.10 log units), on the high side; low and high end bracket the measured number.
By their numbers in this assay, from the lowest: compounds 1, 2 and 3 (each within the scatter of the next).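

Going by these compounds alone, this is the first pair in the set that differs in one place only, so it gives the first direct reading at the sulfonyl sulfur. In this assay, putting 3-chlorophenyl in place of 4-(trifluoromethyl)phenyl gives no change at the digits printed from compound 1 to compound 3 (within the scatter), even though the group that leaves has 10 heavy atoms and the one that enters has 7, and the substituent on the ring differs in both kind and printed location. So, for this one pair, the read-out stays level across that swap, although nothing here explains why the two numbers match.

As far as these compounds go, a single swap cannot separate the effect of the ring substituent's identity from that of its location, so it remains open whether chlorine and trifluoromethyl would also stand level if each were placed at the other's printed location on the phenyl ring. Also open, from the compounds shown here alone, is how far this level result extends, for example to a phenyl ring carrying an amine or a carboxylic acid, or to a simple methyl group or a longer alkyl chain on the sulfonyl sulfur instead of a ring.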